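This account rests on a few compounds, and the source may have more. Where it says the series, first, only, none or still open, it means among the compounds named here.

The three measured compounds share one core, seen in compound 1 `Cc1cc(C(=O)NCc2ccccc2)nn1Cc1cc(Cl)ccc1OCc1ccccc1`, compound 2 `Cc1cc(C(=O)NCc2cccnc2)nn1Cc1cc(Cl)ccc1OCc1ccccc1` and compound 3 `Cc1cc(NC(=O)c2ccccc2)nn1Cc1cc(Cl)ccc1OCc1ccccc1`, and the property followed is a physicochemical assay for lipophilicity, at pH 7.4; on this read-out higher numbers stand for higher lipophilicity and lower numbers for lower lipophilicity. For compound 1 the result is a limit of the assay rather than a number: compound 1 gives > 3.7. Compound 2 likewise reaches a limit: compound 2 gives > 3.7. Compound 3 also stands at a limit: compound 3 gives > 3.7. Because every value sits at the limit of > 3.7 in this assay, at which 3 of the 3 values shown sit, the steps between these compounds cannot be sized: a step that the two limits leave unreadable from compound 1 to compound 2, a step that the two limits leave unreadable from compound 1 to compound 3 and a step that the two limits leave unreadable from compound 2 to compound 3. Compound 3 thus stands at the top of what this assay reports, alongside both others.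

Compound 4 `Cc1cc(NC(=O)OCc2ccccc2)nn1Cc1cc(Cl)ccc1OCc1ccccc1` is the next compound. The change is benzyloxy in place of phenyl on a carbonyl carbon. Among the measured compounds shown here, none of the measured steps is readable, so none gives a size to lean on; the shared limit suggests compound 4 will again reach it. The expected step is a step that the limit leaves unreadable from compound 3 to compound 4. For compound 4 the estimate in this assay is 4.2, between 3.7 and 4.9.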

Compound 4, distribution coefficient: 3.1
Beside the measured number, compound 4's estimate is 1.10 log units above it; measured number below the stated range.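

In this assay, among the compounds shown here, this carbonyl carbon is the first place where a change gives a readable result: benzyloxy in place of phenyl gives a number at least 0.60 log units lower from compound 3 to compound 4 (beyond the scatter). Replacing the whole group on the aromatic carbon tells the same story, with (benzyloxycarbonyl)amino in place of ((pyridin-3-yl)methyl)carbamoyl giving a number at least 0.60 log units lower from compound 2 to compound 4 (beyond the scatter), and in place of benzylcarbamoyl giving a number at least 0.60 log units lower from compound 1 to compound 4 (beyond the scatter). The entering benzyloxy is the larger group and carries a hydrogen-bond acceptor where phenyl has none, and each step is only a minimum because the other end of it is a limit of the assay: the limit of > 3.7 in this assay, at which 3 of the 4 values shown sit.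

The compounds shown do not separate the oxygen from the longer link, which a 2-phenylethyl group on the same carbonyl carbon could do. From the compounds shown here alone, how an amine or a carboxylic acid in this place would read also stays open.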